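The compounds below may be only part of what the source reports. "The series", "measured", "known", "first", "only" and "open" are said of these compounds alone.

Measured compounds in a functional assay on CCRF-CEM cells for agonist activity at C-X-C chemokine receptor type 4 (Homo sapiens), read by calcium flux, with a stated time of 25 min; on this read-out higher numbers stand for an effect only at larger amounts of compound and lower numbers for an effect already at smaller amounts:
Compound 1 `Cc1cnc(CN(C)C[C@H]2Cc3c(cccc3N3CCNCC3)CN2)c(C)c1` gives > 30000 nM, a limit of the assay.
Compound 2 `CN(C[C@H]1Cc2c(cccc2N2C[C@@H]3C[C@H]2CN3)CN1)[C@H]1CCCc2cccnc21` gives > 30000 nM, likewise a limit of the assay.

Compound 2 stands on no number of its own: in this assay it reached only the limit, and the other value shown, that of compound 1, is also a limit, so the two sit together at the limit of > 30000 nM in this assay, at which 2 of the 2 values shown sit, and nothing orders them. Compound 3 `CN(C[C@H]1Cc2c(cccc2N2CCNCC2)CN1)[C@H]1CCCc2cccnc21` has not yet been measured in this assay. It differs from compound 2 in one place: a group of 6 heavy atoms (4 carbon, 2 nitrogen; one six-membered non-aromatic ring with 2 hetero atoms) in place of a group of 7 heavy atoms (5 carbon, 2 nitrogen; 2 five-membered non-aromatic rings with 1 hetero atom each), on an aromatic carbon, a piperazin-1-yl on an aromatic carbon of the shared core. Compound 1 already carries a piperazin-1-yl on the same core and gave only a limit, so no move beyond the scatter is expected from compound 2 to compound 3, in either direction; the expected step is a number no higher from compound 2 to compound 3 (the limit leaves the size open). For compound 3 the estimate in this assay is 30000 nM, between 10000 nM and 100000 nM.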

Compound 3, half-maximal effective concentration: > 30000 nM
Compound 3 ended at the assay's limit; the forecaster's own chance of this, stated with the estimate: 80%; the middle value lies on the limit itself.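

Among these compounds, compound 2 and compound 3 both ended at a limit of the assay and not at a number, so no step between them can be read. The compounds shown leave open how the piperazin-1-yl and the group it replaces rank in this assay at all.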